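A few compounds are considered here, and "the series" means these few. Any claim that something is new, unique, unknown or untested is made for them only; others in the source may bear on it.

Of the compounds shown here, three sharing one core have been tested in a functional assay on HGC-27 cells (Homo sapiens) for inhibition, read by MTT assay, with a stated time of 72 h; on this read-out lower numbers stand for stronger inhibition and higher numbers for weaker inhibition. Compound 1 `Cc1cc(N2CC[C@@H](C)[C@@H](N(C)c3ncnc4[nH]ccc34)C2)n2nc(SCc3ccccc3)nc2n1` gives 13900 nM, the second highest of the three numbers. Compound 2 `Cc1cc(N2CC[C@@H](C)[C@@H](N(C)c3ncnc4[nH]ccc34)C2)n2nc(SCCc3ccccc3)nc2n1` gives 11800 nM, and compound 3 `C=CCSc1nc2nc(C)cc(N3CC[C@@H](C)[C@@H](N(C)c4ncnc5[nH]ccc45)C3)n2n1` gives 35200 nM. Lengthening the chain changed little, since a 1.2-fold lower number from compound 1 to compound 2 (0.07 log units; within the scatter), whereas a 2.5-fold higher number from compound 1 to compound 3 (0.40 log units; beyond the scatter) and a 3.0-fold higher number from compound 2 to compound 3 (0.47 log units; beyond the scatter), so a small chain in place of the ring weakened inhibition modestly. Compound 4 `CCCSc1nc2nc(C)cc(N3CC[C@@H](C)[C@@H](N(C)c4ncnc5[nH]ccc45)C3)n2n1` differs from compound 1 in one place: ethyl in place of phenyl on a saturated chain carbon bound to a sulfur. Because a 2.5-fold higher number from compound 1 to compound 3 (0.40 log units; beyond the scatter), where vinyl is likewise a short chain in place of the ring, a modest rise in number is expected for compound 4, estimated as a 2.2-fold higher number from compound 1 to compound 4 (0.33 log units; beyond the scatter). Compound 4 is therefore expected to give about 30000 nM, within the range 12000 nM to 75000 nM.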

Compound 4, half-maximal inhibitory concentration: 20900 nM
Compound 4: the middle estimate sits 1.4-fold (0.16 log units) above what was measured; low and high end bracket the measured number.
By their numbers in this assay, from the lowest: compounds 2, 1, 4 and 3 (each within the scatter of the next, the first and the last beyond it).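

In this assay replacing benzylsulfanyl with propylsulfanyl gives a 1.5-fold higher number from compound 1 to compound 4 (0.18 log units; within the scatter) and so brings no clear loss of inhibition. The longer ring-bearing chain of compound 2 reads the same way, with a 1.8-fold higher number from compound 2 to compound 4 (0.25 log units; within the scatter) and the saturated chain cannot be told apart from the vinyl-ended chain, with a 1.7-fold lower number from compound 3 to compound 4 (0.23 log units; within the scatter) as the third step. The phenyl ring is therefore not shown to be required at this position, although compound 3 still lies beyond the scatter of both ring-bearing compounds. On these data alone, whether an amine or a carboxylic acid on this chain would move the number further remains open. Nothing measured here explains these small steps.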